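Swapping the aryl tail: fluoropyridine to carboxypyridine

The source may hold more compounds than are shown below. What is called first, only, known or untested is meant among the compounds shown, and "the series" means these compounds.

Measured compounds:
Compound 1, `CCC(C)(C)Cc1c[nH]c(CCc2ccc(-c3ccccc3C(=O)O)cc2)n1`: 11 nM
Compound 2, `CCC(C)(C)Cc1c[nH]c(CCc2ccc(-c3ccc(F)cn3)cc2)n1`: 19 nM
Compound 3, `c1ccc(-c2ccc(CCc3nc(CC4CCCC4)c[nH]3)cc2)nc1`: 177 nM

All three were tested in an in vitro assay on CHO cells for displacement of a labelled ligand from Bombesin receptor subtype-3 (Homo sapiens), read by scintillation counting, with a stated time of 2 h; a lower number here means a stronger inhibitor, a higher number a weaker inhibitor. Compound 2 gives the second highest of the three numbers; compound 1 sits closest, and compound 3 furthest away. For the measured compounds named here, the one single-site step recorded, a 1.7-fold higher number from compound 1 to compound 2 (0.24 log units; within the scatter), shows that replacing a carboxyphenyl with a fluoropyridinyl barely moves the number. Compound 4, `CCC(C)(C)Cc1c[nH]c(CCc2ccc(-c3cccnc3C(=O)O)cc2)n1`, is not yet measured; it differs from compound 2 by 2-carboxypyridin-3-yl in place of 5-fluoropyridin-2-yl on an aromatic carbon. The entering group carries the carboxylic acid seen in compound 1, so the expected result is a return toward the number of compound 1, a modest step in this assay, estimated as a 1.6-fold lower number from compound 2 to compound 4 (0.20 log units; within the scatter). For compound 4 the estimate is 12 nM, within 5 nM to 30 nM.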

Compound 4, half-maximal inhibitory concentration: 560 nM
Estimate against measurement, compound 4: 47-fold (1.67 log units) below; the whole stated range lies below it.
By their numbers in this assay, from the lowest: compounds 1 and 2 (each within the scatter of the next); then compound 3; then compound 4.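

The carboxylic acid alone does not secure a low number at this position: with the acid kept, 2-carboxypyridin-3-yl in place of 2-carboxyphenyl gives a 51-fold higher number from compound 1 to compound 4 (1.71 log units; beyond the scatter) in this assay. The earlier close pair of compound 1 and compound 2 made this position look forgiving, yet the change here gives a 29-fold higher number from compound 2 to compound 4 (1.47 log units; beyond the scatter), so the exact aryl group matters greatly. Nothing available explains this loss. As far as these compounds go, it remains open how a methyl ester or a primary amide would read in place of the carboxylic acid on this pyridine ring.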